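Cytotoxicity in a trifluoromethyl-pyrimidinone series: weak across the board

This account rests on a few compounds, and the source may have more. Where it says the series, first, only, none or still open, it means among the compounds named here.

Measured compounds:
compound 1, `CCc1cc(C)nn1-c1nc(C(F)(F)F)cc(=O)[nH]1`, 108000 nM in an ADME assay on CHO cells (Cricetulus griseus) for cytotoxicity, read by MTT assay; on this read-out higher numbers stand for weaker inhibition and lower numbers for stronger inhibition
compound 2, `Cc1cc(-c2ccccc2)n(-c2nc(C(F)(F)F)cc(=O)[nH]2)n1`, > 50000 nM
compound 3, `Cc1cc(NCCN(C)C)n(-c2nc(C(F)(F)F)cc(=O)[nH]2)n1`, "not determined" (no result reported)

Compound 1 gives a plain number in this assay, and that number is the only one in the set. Compound 2 reaches only a limit of the assay, > 50000 nM, as recorded in the limit of > 50000 nM in this assay, at which 1 of the 3 values shown sits. Among the compounds with values here, the single step that has been measured, a step that the limit leaves unreadable from compound 1 to compound 2, is therefore unreadable in size. Within the data shown here, compound 3 has no result at all in this assay, so it stands nowhere on the numbers; the only further value beside compound 1 is the limit of compound 2.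

Compound 4, `Cc1cc(Nc2ccc(F)cc2F)n(-c2nc(C(F)(F)F)cc(=O)[nH]2)n1`, differs from compound 3 by 2,4-difluorophenyl in place of 2-(dimethylamino)ethyl on a nitrogen on an aromatic ring. Among the measured compounds shown here, no measured step bears on this change, and compound 3 itself has no value, so no direction or size can be read for the step in this assay. What the two measured compounds show is weak inhibition for both. Compound 4 is accordingly expected to give about 80000 nM, between 30000 nM and 200000 nM, with a fair chance of only a limit being reported.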

Compound 4, half-maximal inhibitory concentration: 8000 nM
Compound 4: the middle estimate sits 10-fold (1.00 log units) above what was measured; measured number below the stated range.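

No new step can be read: compound 3 has no number in this assay, so the change from compound 3 to compound 4 cannot be sized. The compounds shown leave open whether the 2,4-difluorophenyl group is what goes with the value of compound 4, 8000 nM.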